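Swapping a Halogen for an Ethoxy Group

The source may report more compounds than this note shows. Statements on the series, on what has been measured and on what is new or still open speak of the compounds shown alone.

In a functional assay on HepG2 cells (Homo sapiens) for cytotoxicity, read by MTT assay (on this read-out lower numbers stand for stronger inhibition and higher numbers for weaker inhibition), compound 1 `C=C1C(=O)[C@]23C[C@@]1(Cl)CC[C@H]2[C@@]12C=CC(=O)[C@](C)(C(=O)O1)[C@H]2[C@@H]3C(=O)OCc1ccccc1` gives 17900 nM, the lowest of the two numbers measured. Among the compounds with values here, compound 2 `C=C1C(=O)[C@]23C[C@@]1(I)CC[C@H]2[C@@]12C=CC(=O)[C@](C)(C(=O)O1)[C@H]2[C@@H]3C(=O)OCc1ccccc1` gives 69500 nM; the only measured step, a 3.9-fold higher number from compound 1 to compound 2 (0.59 log units; beyond the scatter), arose from iodo in place of chloro on a saturated ring carbon. Compound 3 `C=C1C(=O)[C@]23C[C@@]1(OCC)CC[C@H]2[C@@]12C=CC(=O)[C@](C)(C(=O)O1)[C@H]2[C@@H]3C(=O)OCc1ccccc1` differs from compound 1 in one place: ethoxy in place of chloro on a saturated ring carbon. That single step swaps one halogen for another, so it bears only loosely on an ethoxy group, and the direction is uncertain. I expect a step of a 1.7-fold higher number from compound 1 to compound 3 (0.22 log units; within the scatter). For compound 3 the estimated value is 30000 nM, with a range from 10000 nM to 90000 nM.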

Compound 3, half-maximal inhibitory concentration: 29600 nM
Beside the measured number, compound 3's estimate is 1.0-fold (0.01 log units) above it; measured number inside the range.
By their numbers in this assay, from the lowest: compounds 1 and 3 (each within the scatter of the next); then compound 2.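

Ethoxy is the first group here at this saturated ring carbon that is not a halogen, and this assay shows only a 1.7-fold higher number from compound 1 to compound 3 (0.22 log units; within the scatter), so chloro and ethoxy cannot be told apart. Within the data shown here, replacing iodo with ethoxy gives a 2.3-fold lower number from compound 2 to compound 3 (0.37 log units; beyond the scatter), which leaves iodo as the one group of these three that stands apart. Nothing available here explains these differences. Going by these compounds, whether an amine, a carboxylic acid or a longer chain at this carbon would keep, lower or raise the number remains open.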